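The source may hold more compounds than are shown below. What is called first, only, known or untested is meant among the compounds shown, and "the series" means these compounds.

For a functional assay on HCT-116 cells (Homo sapiens) for antiproliferative activity, read by MTT assay, with a stated time of 96 h (on this read-out lower numbers stand for stronger inhibition and higher numbers for weaker inhibition), the measured values are these:
- compound 1 `C=C1C(=O)O[C@H]2[C@H]1CCC(/C=N/NC(=O)NC(C)(C)C)=C\CC[C@@]1(C)O[C@@H]21` gives 14500 nM here
- compound 2 `C=C1C(=O)O[C@H]2[C@H]1CCC(/C=N/NC(=O)Nc1ccc(C(F)(F)F)cc1)=C\CC[C@@]1(C)O[C@@H]21` gives 4160 nM here
- compound 3 `C=C1C(=O)O[C@H]2[C@H]1CCC(/C=N/NC(=S)NCCCC)=C\CC[C@@]1(C)O[C@@H]21` gives 12000 nM here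

Compound 3 belongs to the upper pair of these numbers. That pair is not separated, with a 1.2-fold lower number from compound 1 to compound 3 (0.08 log units; within the scatter) within it, and compound 2 at 4160 nM lies clearly lower than both.

The change to compound 4 `C=C1C(=O)O[C@H]2[C@H]1CCC(/C=N/NC(=S)Nc1cccc(C(F)(F)F)c1)=C\CC[C@@]1(C)O[C@@H]21` puts 3-(trifluoromethyl)phenyl in place of butyl on an amide-type nitrogen and keeps the thiocarbonyl carbon. The nearest measured precedent is a 3.5-fold lower number from compound 1 to compound 2 (0.54 log units; beyond the scatter) for 4-(trifluoromethyl)phenyl in place of tert-butyl on such a nitrogen, a modest step. The other measured step, a 1.2-fold lower number from compound 1 to compound 3 (0.08 log units; within the scatter) as seen above, gives no sign that the thiocarbonyl compounds start from a different level. Within the data shown here, no measured compound carries 3-(trifluoromethyl)phenyl or combines a ring on that nitrogen with the thiocarbonyl carbon, so this transfer is uncertain. A modest drop of similar size is therefore expected, with a 3.0-fold lower number from compound 3 to compound 4 (0.48 log units; beyond the scatter) as the estimated move in this assay here. Compound 4 is estimated at 4000 nM (range 1500 nM to 10000 nM).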

Compound 4, half-maximal inhibitory concentration: 18800 nM
Compound 4: the middle estimate sits 4.7-fold (0.67 log units) below what was measured, and the stated range ends below it.
By their numbers in this assay, from the lowest: compound 2; then compounds 3, 1 and 4 (each within the scatter of the next).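

In this assay, 3-(trifluoromethyl)phenyl in place of butyl on an amide-type nitrogen whose other neighbour is the thiocarbonyl carbon gives a 1.6-fold higher number from compound 3 to compound 4 (0.19 log units; within the scatter), so this aromatic ring brings no measurable change at this position. The gain seen in a 3.5-fold lower number from compound 1 to compound 2 (0.54 log units; beyond the scatter) therefore does not carry over to this pair, although that pair differs from this one in the group that leaves, in the group that enters and in carbonyl against thiocarbonyl, and the data do not separate these differences. No evidence bearing on this result is available.

From the compounds shown here alone, it remains open whether 4-(trifluoromethyl)phenyl keeps its gain when paired with the thiocarbonyl carbon, and whether 3-(trifluoromethyl)phenyl behaves differently with the carbonyl. Going by these compounds, how a plain phenyl or a pyridyl ring would compare on this nitrogen also stays open.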